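The compounds below may be only part of what the source reports. "The series", "measured", "known", "first", "only" and "open" are said of these compounds alone.

Measured in a physicochemical assay for lipophilicity, read by HPLC, in phosphate buffer, measured as chromatographic lipophilicity, at pH 7.4; on this read-out higher numbers stand for higher lipophilicity and lower numbers for lower lipophilicity:
compound 1 `Cc1cc(C)cc(NC(=O)COc2cc(C)nc3ccccc23)c1`: 5.39
compound 2 `COc1ccc2nc(C)cc(OCC(=O)Nc3cc(C)ccc3C)c2c1`: 5.05

Compound 2 gives the lowest of these two numbers; compound 1 sits higher, and that gap lies beyond the usual scatter. The step followed here leads from compound 2 to compound 3 `COc1ccc2nc(C)cc(OCC(=O)NC3CONC3=O)c2c1`, which has not yet been measured in this assay. The change is a group of 6 heavy atoms (3 carbon, 1 nitrogen, 2 oxygen; one five-membered non-aromatic ring with 2 hetero atoms) in place of a group of 8 heavy atoms (8 carbon; one six-membered aromatic ring of carbon only), on an amide-type nitrogen. Within the data shown here, no measured pair shows a swap of this kind, so its size has to be estimated from the counts in the change alone; a large drop is expected. In this assay compound 3 is expected near 2.5, with a range from 1.5 to 3.5. The expected step is a number 2.55 log units lower from compound 2 to compound 3 (beyond the scatter).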

Compound 3, distribution coefficient: 0.79
Beside the measured number, compound 3's estimate is 1.71 log units above it, and the stated range ends above it.
By their numbers in this assay, from the lowest: compound 3; then compound 2; then compound 1.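

In this assay there is a number 4.26 log units lower from compound 2 to compound 3 (beyond the scatter) when the 2,5-dimethylphenyl on the amide-type nitrogen gives way to a five-membered non-aromatic ring with 2 hetero atoms. This shows that a single change at this place can move the number far more than the gap between the two earlier compounds. Nothing measured here says why the number falls so far.

The change replaces a whole group at once, so the compounds shown do not separate the loss of the aromatic ring from the entry of the hetero atoms. A cyclopentyl ring or a short alkyl chain on the same nitrogen remains an open comparison.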